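The source may hold more compounds than are shown below. What is called first, only, known or untested is meant among the compounds shown, and "the series" means these compounds.

Of the compounds shown here, three built on a shared core have been tested in an ADME assay on MT4 cells (Homo sapiens) for cytotoxicity, read by MTT assay, with a stated time of 96 h; a lower number here means that less compound is tolerated, a higher number that more compound is tolerated. Compound 1, `O=C(O)CCC(=O)Nc1ccc(-c2nc3cc(C(F)(F)F)ccc3[nH]2)cc1`, reaches only the limit of the assay, (the limit of > 100000 nM in this assay, at which 1 of the 3 values shown sits), so its reading of > 100000 nM is a limit and not a number. Compound 2, `O=[N+]([O-])c1ccc(-c2nc3cc(C(F)(F)F)ccc3[nH]2)cc1`, gives 6000 nM. The step of an at least 16-fold lower number from compound 1 to compound 2 (1.22 log units; beyond the scatter) is the only one in which two measured compounds differ in a single place. Compound 3, `O=C(CN1CCCC1)Nc1ccc(-c2nc3ccccc3[nH]2)cc1`, gives 40000 nM, the highest of the two readings that are numbers, with compound 2 as its nearest neighbour at a lower number. The unmeasured compound 4, `O=C(CN1CCCC1)Nc1ccc(-c2nc3cc(C(F)(F)F)ccc3[nH]2)cc1`, differs from compound 3 as trifluoromethyl in place of hydrogen on an aromatic carbon. Within the data shown here, no measured step concerns this change: the one measured step exchanges a group on the far ring while both of its compounds already carry the trifluoromethyl, and compound 3 lacks it, so no pair of numbers shows what the trifluoromethyl alone does to the number. Lacking such a comparison, the expected step of a 1.3-fold lower number from compound 3 to compound 4 (0.12 log units; within the scatter) is taken as none beyond the scatter. Compound 4 is therefore estimated at 30000 nM in this assay, with a range from 10000 nM to 100000 nM.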

Compound 4, half-maximal cytotoxic concentration: 18000 nM
Compound 4: middle estimate off by 1.7-fold (0.22 log units), on the high side, and the stated range covers the measured number.
By their numbers in this assay, from the lowest: compound 2; then compound 4; then compound 3. At a limit, above all of these: compound 1.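

In this assay, among these compounds, the step of a 2.2-fold lower number from compound 3 to compound 4 (0.35 log units; beyond the scatter) is the first direct reading of trifluoromethyl in place of hydrogen on an aromatic carbon, and it is modest but beyond the scatter. With the trifluoromethyl present in both compounds, the step of a 3.0-fold higher number from compound 2 to compound 4 (0.48 log units; beyond the scatter) shows a modest change for (((pyrrolidin-1-yl)methyl)carbonyl)amino in place of nitro, which places compound 4 between compound 2 and compound 3 in this order of tolerance. The step of an at least 5.5-fold lower number from compound 1 to compound 4 (0.74 log units; beyond the scatter), for pyrrolidin-1-yl in place of carboxymethyl, starts from a limit and not a number, so it gives only a bound: the limit of > 100000 nM in this assay, at which 1 of the 4 values shown sits.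

As far as these compounds go, the trifluoromethyl change is read on a single pair, so it remains open whether a step of like size and direction would appear in compounds carrying nitro or the carboxylic acid chain instead. Also open, from the compounds shown here alone, is how the number would respond to a chlorine atom or a methyl group on that aromatic carbon, or to a piperidine or an open-chain amine in place of pyrrolidin-1-yl.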